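Notes on a lactone series in a cell growth assay

This account rests on a few compounds, and the source may have more. Where it says the series, first, only, none or still open, it means among the compounds named here.

Of the compounds shown here, three of a shared core have been measured in a functional assay on MCF7 cells (Homo sapiens) for inhibition, read by MTT assay, with a stated time of 72 h; a higher number here means a weaker inhibitor, a lower number a stronger inhibitor. Compound 1 `O=C1O/C(=C\Cn2c(=O)[nH]c(=O)[nH]c2=O)C(OCc2ccccc2)=C1OCc1ccccc1` gives 17800 nM. Compound 2 `NC1(CCn2cc(F)c(=O)[nH]c2=O)OC(=O)C(OCc2ccccc2)=C1OCc1ccccc1` gives 20900 nM, and compound 3 `Nc1ncn(C[C@H](O)[C@H]2OC(=O)C(OCc3ccccc3)=C2OCc2ccccc2)c(=O)n1` gives 73800 nM. Among these three numbers compound 2 stands second highest; its nearest neighbour is compound 1, whose number lies within the usual scatter of it, so no order between the two can be claimed. Compound 3 lies furthest away, with a number beyond the scatter above that of compound 2.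

Compound 4 `Nc1ccn(CCC2(N)OC(=O)C(OCc3ccccc3)=C2OCc2ccccc2)c(=O)n1` has not yet been measured. It differs from compound 2 in one place: a group of 8 heavy atoms (4 carbon, 3 nitrogen, 1 oxygen; one six-membered aromatic ring with 2 hetero atoms) in place of a group of 9 heavy atoms (4 carbon, 2 nitrogen, 2 oxygen, 1 fluorine; one six-membered aromatic ring with 2 hetero atoms), on a saturated chain carbon, two bonds along the chain from a saturated ring carbon. Within the data shown here, no measured pair shows this exact change, so the size of the step has to be judged from the spread of the three measured numbers alone. That spread is narrow, and the replaced and entering groups are of similar size, each holding one six-membered aromatic ring with two hetero atoms. A step from compound 2 to compound 4 within the scatter, or at most modestly weaker, is expected, in line with the weaker number seen for compound 3.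

For compound 4 in this assay the estimate is 28000 nM, with a range from 12000 nM to 65000 nM, and the expected step is a 1.3-fold higher number from compound 2 to compound 4 (0.13 log units; within the scatter).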

Compound 4, half-maximal inhibitory concentration: 32000 nM
For compound 4 the middle estimate is 1.1-fold (0.06 log units) below the measured one; the range from low to high includes it.
By their numbers in this assay, from the lowest: compounds 1, 2 and 4 (each within the scatter of the next); then compound 3.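

Among these compounds, compound 2 and compound 4 form the only pair that differs in one place, and their step in this assay is a 1.5-fold higher number from compound 2 to compound 4 (0.19 log units; within the scatter). The step shows that, on a saturated chain carbon, two bonds along the chain from a saturated ring carbon, the group of 8 heavy atoms (4 carbon, 3 nitrogen, 1 oxygen) can stand in place of the group of 9 heavy atoms (4 carbon, 2 nitrogen, 2 oxygen, 1 fluorine) with no difference that can be told from the scatter, so this exchange of one six-membered aromatic ring with 2 hetero atoms for another gives no measurable handle on the number. No measurement at hand offers an explanation for this outcome.

The compounds shown leave open whether this position would tolerate a group without such a ring, for example a simple amine or a carboxylic acid, and whether a longer chain would shift the number. They also cannot separate the part played by the fluorine from that of the rest of the exchange, as both groups differ in more than that atom.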